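The compounds below may be only part of what the source reports. "The series", "measured", "known", "first", "only" and "open" are said of these compounds alone.

Measured so far:

Compound 1, `COc1ccc(NC(=O)Nn2c(-c3ccccc3)nc3ccccc3c2=O)cc1`: 52%
Compound 2, `O=C(Nc1ccccc1)Nn1c(-c2ccccc2)nc2ccccc2c1=O`: 56%
Compound 3, `CCc1nc2ccccc2c(=O)n1NC(=O)Nc1ccccc1`: 54%

All three were tested in a functional assay on the whole organism (strain albino) with Mus musculus as the target, at a dose of 100 mg/kg by the intraperitoneal route; on this read-out higher numbers stand for more inhibition at the one dose given (going by the name of the read-out) and lower numbers for less inhibition. Compound 3 has the second highest of the three numbers, but its neighbours lie close on either side: compound 1 is near it, and compound 2 is only slightly further off, both inside the usual scatter, so the three compounds cannot be told apart on these numbers.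

Compound 4, `CCc1nc2ccccc2c(=O)n1NC(=O)Nc1ccc(Cl)cc1`, is the next step. Compared with compound 3 it carries chloro in place of hydrogen on an aromatic carbon, on an aromatic carbon of a six-membered aromatic ring of carbon only, para to a large group.

For the measured compounds named here, only one earlier step touches that same ring: a number 4 percentage points higher from compound 1 to compound 2 (within the scatter). A swap on that ring of a group for hydrogen thus moved nothing beyond the scatter. The other step, a number 2 percentage points lower from compound 2 to compound 3 (within the scatter), concerns a different part of the molecule. Nothing measured involves chloro itself. The expectation for compound 4 is therefore no step beyond the scatter, no change at the digits printed from compound 3 to compound 4 (within the scatter), with compound 4 estimated at 54%, between 40% and 68%.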

Compound 4, a percentage reported as inhibition, in the whole organism at one dose (the size of the read-out at that dose, not a potency): 52%
Compound 4: the middle estimate sits 2 percentage points above what was measured, and the stated range covers the measured number.
By their numbers in this assay, from the lowest: compounds 1, 4, 3 and 2 (each within the scatter of the next).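

In this assay, putting chloro in place of hydrogen on the aromatic ring, para to a large group, gives a number 2 percentage points lower from compound 3 to compound 4 (within the scatter). This shows that a single chlorine atom at this position, on the ethyl-bearing core of compound 3, produces no change this read-out can separate from ordinary scatter, and the earlier swap between methoxy and hydrogen on the phenyl-bearing core also stayed within the scatter. No independent measurement here bears on why this position responds so little.

From the compounds shown here alone, it remains open whether an amine or a carboxylic acid at this position would move the number beyond the scatter, and whether chloro would behave the same way on the core of compound 2. Readings at a single dose also leave open how these compounds would compare at other doses.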